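Trimming the piperazine of compound 2

The compounds below may be only part of what the source reports. "The series", "measured", "known", "first", "only" and "open" are said of these compounds alone.

Of the compounds shown here, two so far have numbers in an ADME assay on Caco-2 cells (Homo sapiens) for permeability; a higher number here means that the compound crosses the layer faster, a lower number that the compound crosses the layer more slowly. Compound 1 `Cc1cn2cc(-c3cc4ccc(N5CCN(C)CC5)cc4oc3=O)nc2cn1` gives 2.7 10^-6 cm/s and compound 2 `CCN1CCN(c2ccc3cc(-c4cn5cc(C)nc(C)c5n4)c(=O)oc3c2)C[C@@H]1C` gives 1.2 10^-6 cm/s in this read-out. Compound 2 is the lower of the two, and its gap to compound 1 lies beyond the usual scatter.

The next compound is compound 3 `Cc1cn2cc(-c3cc4ccc(N5CCN(C)CC5)cc4oc3=O)nc2c(C)n1`, which has no number yet in this assay. It carries 4-methylpiperazin-1-yl in place of the 4-ethyl-3-methylpiperazin-1-yl of compound 2, on an aromatic carbon of a six-membered aromatic ring of carbon only (4-methylpiperazin-1-yl in place of 4-ethyl-3-methylpiperazin-1-yl on an aromatic carbon).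

Among the compounds with values here, no measured pair isolates this change, so any expectation is weak. Within the data shown here, the only guide is the spread of the two values, with compound 2 at 1.2 10^-6 cm/s as the lower end and compound 1 at 2.7 10^-6 cm/s as the upper end. A small rise is expected, and it is not expected to clear the scatter: the estimated step is a 1.7-fold higher number from compound 2 to compound 3 (0.22 log units; within the scatter) (an expectation, not a measurement). For compound 3 the expected value is 2 10^-6 cm/s (estimated range 0.9 10^-6 cm/s to 4.5 10^-6 cm/s).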

Compound 3, apparent permeability: 1.4 10^-6 cm/s
The estimate for compound 3 lay 1.4-fold (0.15 log units) above the measured number, and the stated range covers the measured number.
By their numbers in this assay, from the lowest: compounds 2, 3 and 1 (each within the scatter of the next, the first and the last beyond it).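

In this assay, 4-methylpiperazin-1-yl in place of 4-ethyl-3-methylpiperazin-1-yl on the aromatic carbon gives a 1.2-fold higher number from compound 2 to compound 3 (0.07 log units; within the scatter) and so leaves the read-out within the scatter, even though the ethyl, one methyl and the defined stereocentre all go at once. The second single change now readable, methyl in place of hydrogen on an aromatic carbon of the shared core, gives a 1.9-fold lower number from compound 1 to compound 3 (0.29 log units; within the scatter) and also stays within the scatter. Compound 3 thus links compound 1 and compound 2 by two single changes, neither of which alone clears the scatter in this read-out. No measurement at hand accounts for either step.

The ethyl and the methyl of 4-ethyl-3-methylpiperazin-1-yl leave together in this step, so their separate contributions stay open, and the compounds shown say nothing about whether either stereoisomer of that group would read differently. Also open, as far as these compounds go, is how this read-out responds when the piperazine gives way to a different ring or chain at the same aromatic carbon, such as a morpholine, a piperidine or an open-chain amine.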